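The compounds below may be only part of what the source reports. "The series", "measured", "known", "first", "only" and "open" are said of these compounds alone.

Measured in an assay for inhibition of serine/threonine-protein kinase Sgk1 (Homo sapiens), with stated times of 30 min and 60 min, in the presence of a further agent that is not named here; on this read-out higher numbers stand for weaker inhibition and lower numbers for stronger inhibition:
compound 1, `O=C(NC1CCN(C2CC2)C1)c1cc(-c2ccc(NS(=O)(=O)c3cccc(Cl)c3Cl)cc2)nc2[nH]ncc12`: 6 nM
compound 2, `CNC(=O)c1cc(-c2ccc(NS(=O)(=O)c3cccc(Cl)c3Cl)cc2)nc2[nH]ncc12`: 4 nM
compound 3, `CC(C)NC(=O)c1cc(-c2ccc(NS(=O)(=O)c3cccc(Cl)c3Cl)cc2)nc2[nH]ncc12`: 68 nM

Compound 2 holds the lowest number of the three. Compound 1 sits within the scatter of it, the step being a 1.5-fold lower number from compound 1 to compound 2 (0.18 log units; within the scatter), so the two cannot be ordered. Compound 3 lies well apart: the step of a 17-fold higher number from compound 2 to compound 3 (1.23 log units; beyond the scatter) is large, and so is an 11-fold higher number from compound 1 to compound 3 (1.05 log units; beyond the scatter).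

Compound 4, `CN1CCC(CNC(=O)c2cc(-c3ccc(NS(=O)(=O)c4cccc(Cl)c4Cl)cc3)nc3[nH]ncc23)C1`, is the next member. Against compound 2 the change is 1-methylpyrrolidin-3-yl in place of hydrogen on a saturated chain carbon bound to an amide-type nitrogen; read one bond further out, methylcarbamoyl becomes ((1-methylpyrrolidin-3-yl)methyl)carbamoyl.

Within the data shown here, two measured steps bear on it. From compound 2 to compound 3, isopropyl in place of methyl gave a large rise in the number. From compound 1 to compound 2, a 1-cyclopropylpyrrolidin-3-yl group on the same amide-type nitrogen was exchanged for methyl with no step beyond the scatter, so a pyrrolidine ring carried on that nitrogen is tolerated in compound 1. Compound 4 carries a related ring, set one carbon further out, and the substituent on the amide nitrogen is not isopropyl-like branched at the attachment. The expectation is therefore a step of about a 2.0-fold higher number from compound 2 to compound 4 (0.30 log units; within the scatter) in this assay, close to the scatter and, if anything, toward a higher number. For compound 4 the estimate in this assay is 8 nM, within a range of 3 nM to 30 nM.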

Compound 4, half-maximal inhibitory concentration: 14 nM
Beside the measured number, compound 4's estimate is 1.8-fold (0.24 log units) below it; measured number inside the range.
By their numbers in this assay, from the lowest: compounds 2 and 1 (each within the scatter of the next); then compound 4; then compound 3.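

In this assay, a ring-bearing group on the amide nitrogen is no longer neutral once the ring sits one carbon further out: (1-methylpyrrolidin-3-yl)methyl costs a modest step against methyl (a 3.5-fold higher number from compound 2 to compound 4 (0.54 log units; beyond the scatter)) and a modest step against 1-cyclopropylpyrrolidin-3-yl (a 2.3-fold higher number from compound 1 to compound 4 (0.37 log units; beyond the scatter)), whereas the first two compounds could not be told apart. The same group still stands well clear of isopropyl (a 4.9-fold lower number from compound 3 to compound 4 (0.69 log units; beyond the scatter)), so among these four compounds the number does not rise in order of heavy atoms on this nitrogen, with compound 3 going against that order, since compounds 1 and 4 carry more heavy atoms yet give lower numbers. No measurement here accounts for either the rise or the fall at this position.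

The step between compounds 1 and 4 combines the extra chain carbon with the change from cyclopropyl to methyl on the ring nitrogen, and a 1-methylpyrrolidin-3-yl group placed directly on the amide nitrogen would separate the two. On these data alone, whether the ring nitrogen matters at all stays open, and a cyclopentylmethyl group or a plain ethyl on the amide nitrogen would bear on that.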